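This account rests on a few compounds, and the source may have more. Where it says the series, first, only, none or still open, it means among the compounds named here.

Measured so far in an ADME assay on the whole organism (Rattus norvegicus, strain Sprague-Dawley) for pharmacokinetics, at a dose of 2 mg/kg by the oral route; on this read-out higher numbers stand for higher oral bioavailability and lower numbers for lower oral bioavailability
- compound 1 `CC1(C)C[C@H](c2c[nH]c3c(C(N)=O)cc(-c4ccc(F)cc4)cc23)CCS1(=O)=O` gives 94.1%
- compound 2 `NC(=O)c1cc(-c2ccccc2)cc2c(C3CCS(=O)(=O)CC3)c[nH]c12` gives 97%
- compound 3 `CCS(=O)(=O)N1CCC(c2c[nH]c3c(C(N)=O)cc(-c4ccccc4)cc23)CC1` gives 58%

Compound 2 sits at the top end of these numbers together with compound 1, the two lying within the scatter of each other. Compound 3 lies lower than compound 2 by more than the scatter.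

Compound 4 `NC(=O)c1cc(-c2ccc(F)cc2)cc2c(C3CCS(=O)(=O)CC3)c[nH]c12` changes phenyl of compound 2 to 4-fluorophenyl, with fluoro in place of hydrogen on an aromatic carbon as the difference, fluoro in place of hydrogen on an aromatic carbon. Going by the values given here, no measured pair shows this change alone. Compound 1, which also carries 4-fluorophenyl, gives 94.1% in this assay and stays within the scatter of compound 2. The expected step of a number 7 percentage points lower from compound 2 to compound 4 (within the scatter) is none beyond the scatter. Compound 4 is estimated at 90% (range 72% to 100%).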

Compound 4, oral bioavailability: 47.4%
For compound 4 the middle estimate is 42.6 percentage points above the measured one, and the stated range ends above it.
By their numbers in this assay, from the lowest: compound 4; then compound 3; then compounds 1 and 2 (each within the scatter of the next).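

In this assay, phenyl to 4-fluorophenyl gives a number 49.6 percentage points lower from compound 2 to compound 4 (beyond the scatter), so this place on the ring is sensitive to a single fluoro in place of hydrogen. The group alone does not fix the outcome: compound 1, which also carries 4-fluorophenyl, gives 94.1% on its own core. No measurement shown here accounts for the step. Going by these compounds, whether chloro, methoxy or a nitrile at the same place behaves like fluoro remains open. So does whether the same change on the core of compound 3 gives a step of similar size.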